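Ester chain extension on the thiourea series

The source may hold more compounds than are shown below. What is called first, only, known or untested is meant among the compounds shown, and "the series" means these compounds.

For the measured compounds named here, compound 1 `COC(=O)c1c(NC(=S)Nc2cccc3ccccc23)sc2c1CCCC2` gives 7330 nM in an assay on HEK-Blue hTLR2 cells for agonist activity at Toll-like receptor 2 (Homo sapiens), with a stated time of 24 h (on this read-out lower numbers stand for an effect already at smaller amounts and higher numbers for an effect only at larger amounts of compound), the highest of the two numbers measured so far. Going by the values given here, compound 2 `CC(C)OC(=O)c1c(NC(=S)Nc2cccc3ccccc23)sc2c1CCC2` gives 180 nM in this assay, but it differs from compound 1 in more than one place, so no single-point step is available. Compound 3 `CC(C)COC(=O)c1c(NC(=S)Nc2cccc3ccccc23)sc2c1CCCC2` carries isopropyl in place of hydrogen on a saturated chain carbon bound to an oxygen next to a carbonyl group. Among the compounds with values here, with no isolated step to go on, the expectation leans on the lower number of compound 2: a step downward in this assay of moderate size, beyond the scatter, is expected, as a 4.9-fold lower number from compound 1 to compound 3 (0.69 log units; beyond the scatter). Compound 3 is estimated at 1500 nM, within 400 nM to 6000 nM.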

Compound 3, half-maximal effective concentration: 30500 nM
The estimate for compound 3 lay 20-fold (1.31 log units) below the measured number; the measured number lies above the stated range.
By their numbers in this assay, from the lowest: compound 2; then compound 1; then compound 3.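

Isopropyl in place of hydrogen on a saturated chain carbon bound to an oxygen next to a carbonyl group gives a single-place reading in this assay: a 4.2-fold higher number from compound 1 to compound 3 (0.62 log units; beyond the scatter). On the core of compound 1, then, methoxycarbonyl to isobutoxycarbonyl moves the number up, not down, and this step does not account for compound 2, which differs from compound 1 in more than one place. No measurement on hand bears on the reason for this rise.

Open, on these data alone, is whether an ethyl ester, a straight butyl ester or a carboxylic acid at this position would follow the same direction. Also open, as far as these compounds go, is which difference between compound 1 and compound 2 goes with the lower number of compound 2.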